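This account rests on a few compounds, and the source may have more. Where it says the series, first, only, none or still open, it means among the compounds named here.

Measured so far in a functional assay on MCF7 cells (Homo sapiens) for antiproliferative activity, read by MTT assay, with a stated time of 48 h; a higher number here means a weaker inhibitor, a lower number a stronger inhibitor:

compound 1 `O=[N+]([O-])c1cc(C(F)(F)F)cc([N+](=O)[O-])c1Oc1ccc(Br)cc1/C=N\OCc1ccccc1`: 1150 nM
compound 2 `O=[N+]([O-])c1cc(C(F)(F)F)cc([N+](=O)[O-])c1Oc1ccc(Br)cc1/C=N\OCc1ccccc1F`: 1120 nM

For the measured compounds named here, with only two compounds measured, compound 1 has no distinct rank, as its value lies within the scatter of that of compound 2. The next compound to be tested, compound 3 `O=[N+]([O-])c1cc(C(F)(F)F)cc([N+](=O)[O-])c1Oc1c(Br)cc(Br)cc1/C=N\OCc1ccccc1`, departs from compound 1 by a single change: bromo in place of hydrogen on an aromatic carbon. In words, this is bromo in place of hydrogen on an aromatic carbon, and the new bromo stands ortho to a large group and meta to a bromo group.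

Going by the values given here, only one measured step bears on this change, a 1.0-fold lower number from compound 1 to compound 2 (0.01 log units; within the scatter). It also replaces hydrogen with a halogen on an aromatic carbon, but it involves fluoro rather than bromo and lies at another place in the structure. Among the compounds with values here, that single small step is a weak guide, and no measured compound shows what a second bromo does. No shift beyond the scatter is therefore expected in this assay, in either direction, though the uncertainty stays wide. The estimate is a 1.2-fold lower number from compound 1 to compound 3 (0.06 log units; within the scatter). For compound 3 the expected value is 1000 nM, with an estimated range from 450 nM to 2300 nM.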

Compound 3, half-maximal inhibitory concentration: 1830 nM
The estimate for compound 3 lay 1.8-fold (0.26 log units) below the measured number; the range from low to high includes it.
By their numbers in this assay, from the lowest: compounds 2, 1 and 3 (each within the scatter of the next).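

In this assay, bromo in place of hydrogen on this aromatic carbon, ortho to a large group and meta to a bromo group, gives a 1.6-fold higher number from compound 1 to compound 3 (0.20 log units; within the scatter) and so stays within the usual scatter of repeated measurements. For the compounds shown here, this is the first reading at this carbon and the first of an added bromo, since the earlier fluoro step lay at another place in the structure; it shows that the core of compound 1 can carry a second bromo here with no shift beyond the scatter in this read-out. Nothing measured alongside these numbers accounts for the size of this step, and no cause can be assigned to it.

The compounds shown cover only bromo and hydrogen at this carbon, so they leave open whether a different group here, such as an amine, a methoxy group or a carboxylic acid, would move the number beyond the scatter. They also leave open how the same bromo would behave in combination with the fluoro of compound 2, and what the bromo already present on the core contributes.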